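Chalcone series: hydroxy additions against a flat limit

The source may hold more compounds than are shown below. What is called first, only, known or untested is meant among the compounds shown, and "the series" means these compounds.

Compound 1 `O=C(/C=C/c1ccccc1F)c1ccccc1` is the parent of the first pair. In a functional assay on RAW264.7 cells (Mus musculus) for inhibition, read by fluorescence, with stated times of 1 h, 24 h and 30 min (on this read-out higher numbers stand for weaker inhibition and lower numbers for stronger inhibition), compound 1 gives only a limit, > 10000 nM. Compound 2 `O=C(/C=C/c1ccccc1F)c1cccc(O)c1` differs from it by hydroxy in place of hydrogen on an aromatic carbon. In this assay compound 2 likewise gives only a limit, > 10000 nM. The step that the two limits leave unreadable from compound 1 to compound 2 therefore cannot be sized. Compound 3 `O=C(/C=C/c1ccc(OC(F)(F)F)cc1)c1ccccc1` carries a different core; the difference between the two cores is not broken down here. In this assay compound 3 also gives only a limit, > 10000 nM. Taken together, (the limit of > 10000 nM in this assay, at which 3 of the 3 values shown sit).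

Compound 4 `O=C(/C=C/c1ccc(OC(F)(F)F)cc1)c1ccccc1O`, not yet measured, differs from compound 3 by hydroxy in place of hydrogen on an aromatic carbon. This is the same kind of change as from compound 1 to compound 2, but the place differs: ortho to a large group rather than meta to a large group. The step from compound 3 to compound 4 is expected to be a step that the limit leaves unreadable from compound 3 to compound 4, an expectation resting on compound 3 sitting at > 10000 nM and on (the limit of > 10000 nM in this assay, at which 3 of the 3 values shown sit). Compound 4 is estimated at 20000 nM, with a range from 4000 nM to 100000 nM, most likely reported as a limit again.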

Compound 4, half-maximal inhibitory concentration: > 10000 nM
Compound 4 was reported as a limit; the forecaster's own chance of this, stated with the estimate: 80%; the middle value lies beyond the limit too.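

Compound 3 and compound 4 both give only a limit, so no step between them can be read: the limit of > 10000 nM in this assay, at which 4 of the 4 values shown sit.

The compounds shown leave open whether hydroxy in place of hydrogen on an aromatic carbon changes inhibition in this assay at all.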